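Replacing the carboxylic acid by a piperidine amide

The source may report more compounds than this note shows. Statements on the series, on what has been measured and on what is new or still open speak of the compounds shown alone.

Measured so far, in a functional assay on 143B cells (Homo sapiens) for inhibition, read by MTT assay, with a stated time of 72 h; on this read-out lower numbers stand for stronger inhibition and higher numbers for weaker inhibition:
compound 1 `O=C(O)CCC(=O)OCCCCCCSc1ccc([N+](=O)[O-])c2nonc12` gives 2830 nM;
compound 2 `O=C(CCC(=O)OCCCCCCSc1ccc([N+](=O)[O-])c2nonc12)Nc1ccccc1` gives 3850 nM;
compound 3 `CN(C)CCCNC(=O)CCC(=O)OCCCCCCSc1ccc([N+](=O)[O-])c2nonc12` gives 1180 nM.

Compound 1 sits second highest of the three numbers; its step to compound 2 is a 1.4-fold higher number from compound 1 to compound 2 (0.13 log units; within the scatter), while toward compound 3 it is a 2.4-fold lower number from compound 1 to compound 3 (0.38 log units; beyond the scatter). Compound 4 `O=C(CCC(=O)N1CCCCC1)OCCCCCCSc1ccc([N+](=O)[O-])c2nonc12` differs from compound 1 by piperidin-1-yl in place of hydroxy on a carbonyl carbon. Both measured steps bear on this: converting the acid to an amide gave a 1.4-fold higher number from compound 1 to compound 2 (0.13 log units; within the scatter) in one case and a 2.4-fold lower number from compound 1 to compound 3 (0.38 log units; beyond the scatter) in the other, so a neutral amide such as compound 4 is expected to land between them, with a step of a 1.3-fold lower number from compound 1 to compound 4 (0.11 log units; within the scatter) that is unlikely to exceed the scatter. Compound 4 is therefore estimated at 2200 nM in this assay, within 1000 nM to 5000 nM.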

Compound 4, half-maximal inhibitory concentration: 1900 nM
The estimate for compound 4 lay 1.2-fold (0.06 log units) above the measured number; the range from low to high includes it.
By their numbers in this assay, from the lowest: compounds 3, 4, 1 and 2 (each within the scatter of the next, the first and the last beyond it).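

On this carbonyl carbon in this assay, the piperidin-1-yl ring gives a 1.5-fold lower number from compound 1 to compound 4 (0.17 log units; within the scatter), so a six-membered non-aromatic ring is accepted here without a clear change from hydroxy. The ring also cannot be told apart from the (3-(dimethylamino)propyl)amino group, with a 1.6-fold higher number from compound 3 to compound 4 (0.21 log units; within the scatter), but it does separate, modestly, from anilino, with a 2.0-fold lower number from compound 2 to compound 4 (0.31 log units; beyond the scatter). No evidence is available to explain these numbers. From the compounds shown here alone, whether a morpholine or piperazine ring on this carbonyl carbon would give a similar number stays open.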